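The compounds below may be only part of what the source reports. "The series", "measured", "known", "first", "only" and "open" are said of these compounds alone.

Working notes on the series. In a functional assay on A549 cells (Homo sapiens) for cytotoxicity, read by trypan blue exclusion, with a stated time of 48 h (on this read-out lower numbers stand for stronger inhibition and higher numbers for weaker inhibition), compound 1 `Cc1ccc(-c2csc(NC(=O)COc3ccccc3C)n2)cc1` gives 50100 nM, compound 2 `Cc1ccccc1OCC(=O)Nc1nc(-c2ccc(Br)cc2)cs1` gives 49800 nM and compound 3 `Cc1ccccc1OCC(=O)Nc1nc(-c2ccc(Cl)cc2)cs1` gives 64800 nM. The three measured steps are all small: a 1.0-fold lower number from compound 1 to compound 2 (0.00 log units; within the scatter), a 1.3-fold higher number from compound 1 to compound 3 (0.11 log units; within the scatter) and a 1.3-fold higher number from compound 2 to compound 3 (0.11 log units; within the scatter). Compound 3 therefore stands apart from neither compound 1 nor compound 2 by more than the scatter, and the three compounds form a single flat cluster in this assay.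

Compound 4 `Cc1ccc(OCC(=O)Nc2nc(-c3ccc(Cl)cc3)cs2)cc1` differs from compound 3 by 4-methylphenyl in place of 2-methylphenyl on an oxygen on a saturated carbon. For the measured compounds named here, none of the measured steps touches this part of the molecule; each of them changes the substituent on an aromatic carbon of the other aryl group, and each lies within the scatter. Going by the values given here, there is thus no measured step that bears directly on the change from compound 3 to compound 4, and nothing so far suggests that any single change moves this assay beyond the scatter.

On that basis the step of a 1.1-fold lower number from compound 3 to compound 4 (0.03 log units; within the scatter) is expected to stay within the scatter. Compound 4 is estimated at 60000 nM, with a range from 30000 nM to 120000 nM.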

Compound 4, half-maximal inhibitory concentration: 44800 nM
For compound 4 the middle estimate is 1.3-fold (0.13 log units) above the measured one; the measured number falls inside the stated range.
By their numbers in this assay, from the lowest: compounds 4, 2, 1 and 3 (each within the scatter of the next).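

For the compounds shown here, the step of a 1.4-fold lower number from compound 3 to compound 4 (0.16 log units; within the scatter) is the first measured change on this side of the molecule, and it leaves 2-methylphenyl and 4-methylphenyl on an oxygen on a saturated carbon indistinguishable in this assay. This part of the molecule is therefore as flat so far as the aromatic substituent changes on the other aryl group, with all four compounds still inside one cluster. No supporting measurement bears on why this change has so little effect.

The compounds shown carry only methyl on this phenyl ring, so it remains open whether a different group there, such as an amine or a carboxylic acid, would move the number beyond the scatter. As far as these compounds go, a longer chain between the oxygen and the amide carbonyl also remains open.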